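This account rests on a few compounds, and the source may have more. Where it says the series, first, only, none or still open, it means among the compounds named here.

Measured compounds in an assay on MDA-MB-231 cells for displacement of a labelled ligand from C-X-C chemokine receptor type 4 (Homo sapiens), read by fluorescence and microscopy, with stated times of 10 min and 30 min; on this read-out lower numbers stand for an effect already at smaller amounts and higher numbers for an effect only at larger amounts of compound:
compound 1 `Cc1ccccc1C(=O)NCc1ccc(CNS(=O)(=O)c2ccccc2C)cc1` gives 10 nM
compound 2 `Cc1ccccc1C(=O)NCc1ccc(CNS(=O)(=O)c2ccccc2Cl)cc1` gives 1000 nM
compound 3 `COc1ccccc1C(=O)NCc1ccc(CNS(=O)(=O)c2ccccc2Cl)cc1` gives 100 nM

Compound 2 stands highest of these three numbers in this assay. Its nearest neighbour is compound 3, which sits a 10-fold lower number from compound 2 to compound 3 (1.00 log units; beyond the scatter). Furthest away is compound 1, since the change from compound 1 to compound 2 brought a 100-fold higher number from compound 1 to compound 2 (2.00 log units; beyond the scatter).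

The next compound, compound 4 `Cc1ccccc1C(=O)NCc1ccc(CNS(=O)(=O)c2cccc(F)c2)cc1`, keeps the core of compound 2 and changes the group attached to the sulfonyl sulfur: 3-fluorophenyl in place of 2-chlorophenyl on a sulfonyl sulfur.

For the measured compounds named here, only one measured step touches that part of the molecule, the one in which chloro replaced methyl on an aromatic carbon, giving a 100-fold higher number from compound 1 to compound 2 (2.00 log units; beyond the scatter). It shows that a single substituent change on the ring attached to the sulfonyl sulfur can move the read-out by a large margin. Going by the values given here, nothing measured here shows what a 3-fluorophenyl does at this position, so direction and size cannot be read off; the one step there was large, so a large step is plausible in either direction. On balance compound 4 is expected to lie between the extremes of compound 1 and compound 2, with the step of a 3.3-fold lower number from compound 2 to compound 4 (0.52 log units; beyond the scatter). Compound 4 is estimated at 300 nM, with a range from 30 nM to 3000 nM.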

Compound 4, effective concentration (reported as EC, without a stated level of effect): 100 nM
The estimate for compound 4 lay 3.0-fold (0.48 log units) above the measured number; the measured number falls inside the stated range.
By their numbers in this assay, from the lowest: compound 1; then compounds 3 and 4 (each within the scatter of the next); then compound 2.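

Where the earlier compounds offered only one change on the ring attached to the sulfonyl sulfur, a second change now shows that this position also supports an intermediate result: in this assay 3-fluorophenyl in place of 2-chlorophenyl gave a 10-fold lower number from compound 2 to compound 4 (1.00 log units; beyond the scatter) and 3-fluorophenyl in place of 2-methylphenyl gave a 10-fold higher number from compound 1 to compound 4 (1.00 log units; beyond the scatter) with the rest of the molecule unchanged. Among these three groups on the sulfonyl sulfur, 2-methylphenyl therefore gives the lowest number, 3-fluorophenyl the middle one and 2-chlorophenyl the highest, with every step between them beyond the scatter. No accompanying measurement explains why the numbers fall in this order.

Each step to compound 4 changes both the substituent and its numbered place on the ring, so a 2-fluorophenyl or a 3-chlorophenyl group on the sulfonyl sulfur would be needed to separate those two changes. Also open, from the compounds shown here alone, is how the read-out responds when the phenyl ring here gives way to a pyridine ring or a cyclohexyl group, or when the ring carries a carboxylic acid or an amine.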